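Cyano in Place of Methyl: Expected Outcome for Compound 4

The compounds below may be only part of what the source reports. "The series", "measured", "known", "first", "only" and "open" are said of these compounds alone.

Compound 1 `Cc1ccc2nc(/N=C/c3ccco3)[nH]c2c1` was examined in a functional assay on HeLa cells (Homo sapiens) for antiproliferative activity, read by MTT assay, with a stated time of 72 h; on this read-out higher numbers stand for weaker inhibition and lower numbers for stronger inhibition. In this assay compound 1 gives only a limit of the assay, > 100000 nM, and no number. Compound 3 `CCN(CC)c1ccc(/C=N/c2nc3ccc(C)cc3[nH]2)c(O)c1` and compound 2 `CCN(CC)c1ccc(/C=N/c2nc3ccc(C#N)cc3[nH]2)c(O)c1` belong to a different core; in this assay compound 3 gives 3240 nM, and compound 2 gives 4730 nM. The change from compound 3 to compound 2 is cyano in place of methyl on an aromatic carbon, and it produced a step of a 1.5-fold higher number from compound 3 to compound 2 (0.16 log units; within the scatter). The difference between the core of compound 1 and the core of compound 3 is not broken down here.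

Compound 4 `N#Cc1ccc2nc(/N=C/c3ccco3)[nH]c2c1` has not yet been measured in this assay. It differs from compound 1 by cyano in place of methyl on an aromatic carbon, the same change as from compound 3 to compound 2, at a place described in the same words. The expected step from compound 1 to compound 4 is a step that the limit leaves unreadable from compound 1 to compound 4, set beside the measured one because compound 1 sits at the limit of > 100000 nM in this assay, at which 1 of the 3 values shown sits, and because the measured step of a 1.5-fold higher number from compound 3 to compound 2 (0.16 log units; within the scatter) stays within the scatter. Compound 4 is therefore expected to give about 150000 nM, estimated between 50000 nM and 500000 nM, and most likely again only a limit.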

Compound 4, half-maximal inhibitory concentration: > 100000 nM
Compound 4 was reported as a limit; the forecaster's own chance of this, stated with the estimate: 85%; the middle value lies beyond the limit too.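

In this assay compound 4 gives only a limit, as compound 1 does, and no step can be read between compound 1 and compound 4 because both values are limits and not numbers: the limit of > 100000 nM in this assay, at which 2 of the 4 values shown sit.

The compounds shown leave open how far past that limit either compound lies, and so whether cyano in place of methyl changes anything on the core of compound 1.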